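Methoxy to trifluoromethoxy on compound 2

The source may hold more compounds than are shown below. What is called first, only, known or untested is meant among the compounds shown, and "the series" means these compounds.

Compound 1 `C=C[C@@H]1C[C@]1(NC(=O)[C@@H]1C[C@@H]2CN1C(=O)[C@H](C1Cc3ccccc3C1)NC(=O)OCCC/C=C/c1ccc3ccnc(c3c1)O2)C(=O)NS(=O)(=O)C1CC1` gives 113 ng.h/mL
Compound 2 `C=C[C@@H]1C[C@]1(NC(=O)[C@@H]1C[C@@H]2CN1C(=O)[C@H](C(C)(C)C)NC(=O)OCCCCCc1cc(OC)c3ccnc(c3c1)O2)C(=O)NS(=O)(=O)C1CC1` gives 12800 ng.h/mL

In an in vivo ADME assay on the whole organism (plasma, Rattus norvegicus, strain Sprague-Dawley) for pharmacokinetics, with a stated time of 4 h, at a dose of 5 mg/kg by the oral route (on this read-out lower numbers stand for lower exposure and higher numbers for higher exposure at the dose given), compound 2 holds the higher of the two numbers, and the gap down to compound 1 lies beyond the usual scatter. These two compounds differ in more than one place, so their gap cannot be tied to any single group. Compound 3 `C=C[C@@H]1C[C@]1(NC(=O)[C@@H]1C[C@@H]2CN1C(=O)[C@H](C(C)(C)C)NC(=O)OCCCCCc1cc(OC(F)(F)F)c3ccnc(c3c1)O2)C(=O)NS(=O)(=O)C1CC1` differs from compound 2 in one group only, with trifluoromethyl in place of methyl on an oxygen on an aromatic ring. Going by the values given here, no measured pair shows this change, so the expectation rests on little and stays wide. A small downward step is expected, estimated as a 1.6-fold lower number from compound 2 to compound 3 (0.20 log units; within the scatter) and so not clearly beyond the scatter. For compound 3 the expected exposure is estimated at 8000 ng.h/mL (2500 ng.h/mL to 25000 ng.h/mL).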

Compound 3, area under the concentration-time curve: 1250 ng.h/mL
For compound 3 the middle estimate is 6.4-fold (0.81 log units) above the measured one, and the stated range ends above it.
By their numbers in this assay, from the lowest: compound 1; then compound 3; then compound 2.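

In this assay, going by these compounds alone, the change from methoxy to trifluoromethoxy gives a 10-fold lower number from compound 2 to compound 3 (1.01 log units; beyond the scatter) and so provides the first comparison in this set that differs in one place only. It shows that exposure after an oral dose is sensitive to the group on an oxygen on an aromatic ring, and that trifluoromethyl in place of methyl is a large downward step here. The data offered here give no explanation for this step.

The compounds shown leave open whether difluoromethyl or ethyl in place of methyl on that oxygen would stay nearer compound 2 or compound 3. They also leave open whether the same change would give a step of similar size on the core of compound 1, which differs from compound 2 in more than one place.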